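Methoxy Beside Hydroxy on a Reduced Linker

The compounds below may be only part of what the source reports. "The series", "measured", "known", "first", "only" and "open" are said of these compounds alone.

Compound 1 `COc1ccc2nc(/C=C/c3ccc(O)cc3)c(=O)n(CC(=O)O)c2c1` and compound 2 `COc1ccc2nc(/C=C/c3ccc(O)c(OC)c3)c(=O)n(CC(=O)O)c2c1` share one core and differ only by methoxy in place of hydrogen on an aromatic carbon. In a functional assay, with a stated time of 240 min, tested at 100 uM (on this read-out lower numbers stand for a weaker effect and higher numbers for a stronger effect at the one concentration tested), compound 1 gives 59.2%, while compound 2 gives 83.5%; the step is a number 24.3 percentage points higher from compound 1 to compound 2 (beyond the scatter). Compound 3 `COc1ccc2nc(CCc3ccc(O)cc3)c(=O)n(CC(=O)O)c2c1` has a second core, and the difference between the two cores is not broken down here. In this assay compound 3 gives 20.7%, the lowest of the three numbers. Compound 4 `COc1ccc2nc(CCc3ccc(O)c(OC)c3)c(=O)n(CC(=O)O)c2c1` carries the same change on that second core: methoxy in place of hydrogen on an aromatic carbon. Among the measured compounds shown here, the step from compound 3 to compound 4 is expected to be a number 19.3 percentage points higher from compound 3 to compound 4 (beyond the scatter), somewhat smaller than the earlier one, because compound 3 starts from 20.7% and only one instance of this change has been measured. Compound 4 is therefore expected to give 40% in this assay, within 22% to 62%.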

Compound 4, a percentage reported as activity, at one concentration (the size of the read-out at that concentration, not a potency): 28.3%
The estimate for compound 4 lay 11.7 percentage points above the measured number, within the range that was stated.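

In this assay, the methoxy group on the core of compound 3 gives a number 7.6 percentage points higher from compound 3 to compound 4 (within the scatter). The change did not carry over at the same size from one core to the other: the same change on two cores in this assay, a number 24.3 percentage points higher (beyond the scatter) from compound 1 to compound 2 and a number 7.6 percentage points higher (within the scatter) from compound 3 to compound 4, 16.7 percentage points apart, beyond the scatter of two such steps

So the step seen on the core of compound 1 cannot be assumed for the core of compound 3, although one pair on each core does not show why the steps differ or what a further core would give. The compounds shown leave open whether an ethoxy group or a chlorine in place of the methoxy would also give steps that differ between the two cores. They also leave open what an amine in place of the hydroxy group would give.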